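Replacing an Ether Side Chain with Acetamido: Expected Half-Life

The compounds below may be only part of what the source reports. "The series", "measured", "known", "first", "only" and "open" are said of these compounds alone.

Measured compounds:
compound 1 `CC(C)CCn1nc(-c2cccs2)c(O)c(C2=NS(=O)(=O)c3cc(OC(C)(C)C(N)=O)ccc3N2)c1=O` — 0.35 h
compound 2 `CC(C)CCn1nc(-c2cccs2)c(O)c(C2=NS(=O)(=O)c3cc(OCC(=O)NO)ccc3N2)c1=O` — reported only as a limit, > 1 h
compound 3 `CC(C)CCn1nc(-c2cccs2)c(O)c(C2=NS(=O)(=O)c3cc(NC(=O)C4CC4)ccc3N2)c1=O` — 0.0833 h

In an in vitro ADME assay on microsomes from liver (Homo sapiens) for metabolic stability, tested at 5 uM (on this read-out lower numbers stand for a shorter-lived compound and higher numbers for a longer-lived compound), compound 1 gives 0.35 h, the highest of the two numbers shown, with compound 3 the nearest. For compound 2 the assay reports a limit, (the limit of > 1 h in this assay, at which 1 of the 3 values shown sits). The measured steps are an at least 2.8-fold higher number from compound 1 to compound 2 (0.45 log units; beyond the scatter), a 4.2-fold lower number from compound 1 to compound 3 (0.62 log units; beyond the scatter) and an at least 12-fold lower number from compound 2 to compound 3 (1.07 log units; beyond the scatter).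

Compound 4 `CC(=O)Nc1ccc2c(c1)S(=O)(=O)N=C(c1c(O)c(-c3cccs3)nn(CCC(C)C)c1=O)N2` differs from compound 1 by acetamido in place of 1-carbamoyl-1-methylethoxy on an aromatic carbon. The step from compound 1 to compound 3 bears most on it, since there too an oxygen-linked group gave way to an amino-linked one, and that step was a 4.2-fold lower number from compound 1 to compound 3 (0.62 log units; beyond the scatter). A lower number is therefore expected, a 3.5-fold lower number from compound 1 to compound 4 (0.54 log units; beyond the scatter). Compound 4 is estimated at 0.1 h, within 0.04 h to 0.3 h.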

Compound 4, half-life: 0.055 h
The estimate for compound 4 lay 1.8-fold (0.26 log units) above the measured number, and the stated range covers the measured number.
By their numbers in this assay, from the lowest: compounds 4 and 3 (each within the scatter of the next); then compound 1. At a limit, above all of these: compound 2.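

In this assay, acetamido on this aromatic carbon goes the same way as (cyclopropylcarbonyl)amino did, giving a 6.4-fold lower number from compound 1 to compound 4 (0.80 log units; beyond the scatter). Exchanging cyclopropyl for methyl on the carbonyl carbon gives no readable difference, with a 1.5-fold lower number from compound 3 to compound 4 (0.18 log units; within the scatter). The (hydroxycarbamoyl)methoxy side chain rests on a limit, and against it acetamido gives an at least 18-fold lower number from compound 2 to compound 4 (1.25 log units; beyond the scatter). The compounds shown leave open whether the nitrogen link or the rest of each side chain carries the difference, since both change together. On these data alone, how a plain amine on this carbon, or a carboxylic acid on the oxygen-linked chain, would behave also stays open.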